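A few compounds are considered here, and "the series" means these few. Any claim that something is new, unique, unknown or untested is made for them only; others in the source may bear on it.

Compound 1, `Cc1ccc(C2=NN(C3=NC(=O)CS3)C(c3ccc4ccccc4c3)C2)cc1`, gives 1760 nM in a functional assay on HeLa cells (Homo sapiens) for inhibition, read by CCK-8 assay, with a stated time of 48 h (a lower number here means a stronger inhibitor, a higher number a weaker inhibitor), the lowest of the three numbers recorded. Its nearest neighbour is compound 3, `Cc1ccc(C2=NN(C3=NC(c4ccccc4)CS3)C(c3ccc4ccccc4c3)C2)cc1`, at 2460 nM; the difference a 1.4-fold higher number from compound 1 to compound 3 (0.15 log units; within the scatter) lies within the scatter. Compound 2, `Brc1ccc(C2=NN(C3=NC(c4ccccc4)CS3)C(c3ccc4ccccc4c3)C2)cc1`, at 4960 nM, stands furthest from compound 1, beyond the scatter. The unmeasured compound 4, `O=C1CSC(N2N=C(c3ccc(Cl)cc3)CC2c2ccc3ccccc3c2)=N1`, differs from compound 1 by chloro in place of methyl on an aromatic carbon. Among the measured compounds shown here, the one measured step that bears on this is a 2.0-fold lower number from compound 2 to compound 3 (0.30 log units; within the scatter), a halogen-to-methyl swap at the same position, within the scatter. Reversing that, a halogen in place of methyl in compound 4 is expected to give a slightly higher number, if any change, as a 1.4-fold higher number from compound 1 to compound 4 (0.15 log units; within the scatter). Compound 4 is therefore estimated at 2500 nM, between 1200 nM and 5500 nM.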

Compound 4, half-maximal inhibitory concentration: 6320 nM
Beside the measured number, compound 4's estimate is 2.5-fold (0.40 log units) below it; measured number above the stated range.
By their numbers in this assay, from the lowest: compounds 1, 3, 2 and 4 (each within the scatter of the next, the first and the last beyond it).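

In this assay the change from 4-methylphenyl to 4-chlorophenyl gives a 3.6-fold higher number from compound 1 to compound 4 (0.56 log units; beyond the scatter) and so lies beyond the scatter, while the earlier swap at this position, read as a 2.0-fold lower number from compound 2 to compound 3 (0.30 log units; within the scatter) on a different core, stayed within it. On the core of compound 1, then, this position responds to a halogen in place of methyl more clearly than the earlier pair showed. No measurement to hand accounts for this step. The compounds shown leave open how bromo would read on the core of compound 1, and whether a methoxy group, an amine or a carboxylic acid at this position would give a lower number than methyl.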